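A few compounds are considered here, and "the series" means these few. Any claim that something is new, unique, unknown or untested is made for them only; others in the source may bear on it.

Measured compounds in an ADME assay on Caco-2 cells (Homo sapiens) for permeability, in the apical to basolateral direction; on this read-out higher numbers stand for higher permeability and lower numbers for lower permeability:

Compound 1 `CNC(=O)c1cc(Oc2ccc3nc(Nc4cccc(C(C)(C)C)c4)cnc3c2)ccn1` gives < 1 10^-6 cm/s, which is a limit of the assay rather than a number.
Compound 2 `CNC(=O)c1cc(Oc2ccc3nc(Nc4ccccc4Br)ncc3c2)ccn1` gives < 1 10^-6 cm/s, again a limit of the assay and not a number.
Compound 3 `CNC(=O)c1cc(Oc2ccc3nc(Nc4ccccc4Oc4ccccc4)ncc3c2)ccn1` gives < 1 10^-6 cm/s, also a limit of the assay, not a number.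

Compound 2 therefore stands at a limit in this assay, with no number of its own, and the two other values shown are limits of the same kind. Among the compounds with values here, the only step among the measured compounds that differs in one place is the one from compound 2 to compound 3, where a step that the two limits leave unreadable from compound 2 to compound 3: because of the limit of < 1 10^-6 cm/s in this assay, at which 3 of the 3 values shown sit, its size cannot be read.

The unmeasured compound 4 `CNC(=O)c1cc(Oc2ccc3nc(Nc4cccc(C(F)(F)F)c4)ncc3c2)ccn1` differs from compound 2 in one place: 3-(trifluoromethyl)phenyl in place of 2-bromophenyl on a nitrogen on an aromatic ring. Within the data shown here, no measured step bears directly on this exchange, since the step from compound 2 to compound 3 changes a different group and its size is unreadable. With every value shown sitting at the same limit, there is no measured movement to build on, and no step beyond the scatter is expected from compound 2 to compound 4; the expected step is a step that the limit leaves unreadable from compound 2 to compound 4. Compound 4 is estimated at 0.8 10^-6 cm/s, with a range from 0.3 10^-6 cm/s to 2.5 10^-6 cm/s.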

Compound 4, apparent permeability: < 1 10^-6 cm/s
Compound 4 gave a limit, no number; the forecaster's own chance of this, stated with the estimate: 65%; the middle value is on the limit's open side.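

Compound 2 and compound 4 both give a limit of the assay rather than a number in this assay, so no step between them can be read, because the values offer nothing to compare: the limit of < 1 10^-6 cm/s in this assay, at which 4 of the 4 values shown sit.

The compounds shown leave open how far any of them lies under that limit, and whether any exchange of the group on the nitrogen changes the read-out at all.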